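Tert-butyl for methoxy on compound 1

This account rests on a few compounds, and the source may have more. Where it says the series, first, only, none or still open, it means among the compounds named here.

Compound 1 `COc1ccc(SCc2ccc(C(=O)Nc3ccccc3N)cc2)cc1`: 81.8%
Compound 2 `Nc1ccccc1NC(=O)/C=C/c1ccc(CSc2ccc(F)cc2)cc1`: 24.6%
Compound 3 `Nc1ccccc1NC(=O)/C=C/c1ccc(CSc2cccc3ccccc23)cc1`: 36%

In a functional assay on A-375 cells (Homo sapiens) for inhibition, read by CCK-8 assay, with a stated time of 72 h, tested at 8 uM (on this read-out lower numbers stand for less inhibition of growth and higher numbers for more inhibition of growth at the one concentration tested), compound 1 stands highest of the three at 81.8%, beyond the scatter from both others. Next is compound 4 `CC(C)(C)c1ccc(SCc2ccc(C(=O)Nc3ccccc3N)cc2)cc1`, with tert-butyl in place of methoxy on an aromatic carbon. Within the data shown here, only one measured step bears on this: a number 11.4 percentage points higher from compound 2 to compound 3 (beyond the scatter). It is modest, and it sits on the core of compound 2 and compound 3, not on that of compound 1, so it is a loose guide. With compound 1 already at 81.8%, a modest step downward is expected. The expected change is a number 11.8 percentage points lower from compound 1 to compound 4 (beyond the scatter). For compound 4 the estimate is 70%, with an expected range of 48% to 88%.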

Compound 4, percent growth inhibition at one concentration: 33.1%
Beside the measured number, compound 4's estimate is 36.9 percentage points above it; the measured number lies below the stated range.
By their numbers in this assay, from the lowest: compounds 2, 4 and 3 (each within the scatter of the next, the first and the last beyond it); then compound 1.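

The change of methoxy to tert-butyl on an aromatic carbon, para to a large group, gives a number 48.7 percentage points lower from compound 1 to compound 4 (beyond the scatter). This position on the core of compound 1 is therefore far from indifferent to its substituent, and this single exchange removes most of the growth inhibition. The step is also much larger than the only earlier one, a number 11.4 percentage points higher from compound 2 to compound 3 (beyond the scatter), which lies on a different core. No measured evidence here accounts for the drop.

From the compounds shown here alone, it remains open whether a methyl, a hydroxyl or an amine at this position would retain the activity of compound 1. Whether the same exchange would cost as much on the core of compound 2 is also unresolved.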